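Moving a fluorine around a benzyl ring in an EP1 antagonist

The source may report more compounds than this note shows. Statements on the series, on what has been measured and on what is new or still open speak of the compounds shown alone.

Measured compounds:
compound 1, `COc1ccc(Cc2nnc(CN(c3cccc(Cl)c3C)S(=O)(=O)c3ccc(C)cc3)o2)cc1`, 39.8 nM
compound 2, `Cc1ccc(S(=O)(=O)N(Cc2nnc(Cc3ccccc3F)o2)c2cccc(Cl)c2C)cc1`, 631 nM

In a functional assay on CHO cells for antagonist activity at prostaglandin E2 receptor EP1 subtype (Homo sapiens), read by FLIPR and calcium flux (on this read-out higher numbers stand for weaker inhibition and lower numbers for stronger inhibition), compound 2 gives 631 nM, the highest of the two numbers measured; the nearest is compound 1, which in this assay gives 39.8 nM. For the measured compounds named here, the one measured step, a 16-fold higher number from compound 1 to compound 2 (1.20 log units; beyond the scatter), swaps the whole group on the saturated chain carbon, so it does not test the position of a fluorine on its own.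

Compound 3, `Cc1ccc(S(=O)(=O)N(Cc2nnc(Cc3cccc(F)c3)o2)c2cccc(Cl)c2C)cc1`, differs from compound 2 only in that difference: 3-fluorophenyl in place of 2-fluorophenyl on a saturated chain carbon bound to an aromatic carbon. Going by the values given here, no measured pair speaks directly to this, and the only step available concerns a different group. The expectation is therefore cautious: for compound 3 the step of a 1.6-fold lower number from compound 2 to compound 3 (0.20 log units; within the scatter) in this assay is expected to be small, with wide uncertainty in either direction. Compound 3 is thus estimated at 400 nM, within a range from 100 nM to 1600 nM.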

Compound 3, inhibition constant: 501 nM
Compound 3: the middle estimate sits 1.3-fold (0.10 log units) below what was measured, within the range that was stated.
By their numbers in this assay, from the lowest: compound 1; then compounds 3 and 2 (each within the scatter of the next).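

In this assay, replacing 2-fluorophenyl with 3-fluorophenyl gives a 1.3-fold lower number from compound 2 to compound 3 (0.10 log units; within the scatter), so these two fluorine placements on the saturated chain carbon cannot be told apart. The second fluorophenyl group also stays well separated from 4-methoxyphenyl, with a 13-fold higher number from compound 1 to compound 3 (1.10 log units; beyond the scatter), so the large difference seen earlier is not peculiar to 2-fluorophenyl. The data offer no explanation for either result.

From the compounds shown here alone, it remains open whether the methoxy group itself matters, or whether other groups at this place would match compound 1. A plain phenyl ring would give a baseline without any added group, while a chlorophenyl or an ethoxyphenyl group would show how far the result changes with the group carried on the ring.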